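The source may report more compounds than this note shows. Statements on the series, on what has been measured and on what is new or still open speak of the compounds shown alone.

In a functional assay on MDA-MB-435 cells (Homo sapiens) for cytotoxicity, read by MTT assay, with a stated time of 72 h (a lower number here means a stronger inhibitor, a higher number a weaker inhibitor), compound 1 `CS(=O)(=O)Oc1c(C(=O)NCc2ccc(F)cc2)nc(Br)c2cccnc12` gives only a limit, > 20000 nM. Compound 2 `CS(=O)(=O)NCCCN(c1nc(C(=O)NCc2ccc(F)cc2)c(O)c2ncccc12)S(C)(=O)=O` likewise gives only a limit in this assay, > 20000 nM. Compound 1 therefore stands at the weak edge of what has been seen, the point marked by the limit of > 20000 nM in this assay, at which 2 of the 3 values shown sit. For the measured compounds named here, compound 3 `NCCCNc1c(C(=O)NCc2ccc(F)cc2)ncc2cccnc12` is the one compound with a measured number in this assay, 16000 nM. Compound 4 `N[C@H]1CC[C@H](Nc2c(C(=O)NCc3ccc(F)cc3)nc(Br)c3cccnc23)CC1` has not been measured. It differs from compound 1 in a single place: (4-aminocyclohexyl)amino in place of (methylsulfonyl)oxy on an aromatic carbon. Going by the values given here, no measured pair matches this change, so its size must be guessed. Resting on the number for compound 3, 16000 nM, the expected step is an at least 2.5-fold lower number from compound 1 to compound 4 (0.39 log units; beyond the scatter). The estimate for compound 4 is 8000 nM, with a range from 1500 nM to 30000 nM.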

Compound 4, half-maximal inhibitory concentration: 6000 nM
Compound 4: middle estimate off by 1.3-fold (0.12 log units), on the high side, and the stated range covers the measured number.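

In this assay, putting (4-aminocyclohexyl)amino in place of (methylsulfonyl)oxy on this aromatic carbon, para to a bromo group, gives an at least 3.3-fold lower number from compound 1 to compound 4 (0.52 log units; beyond the scatter). This is the only pair shown that differs in one place, so a change at this position now has a measured direction. The true size of the step stays unknown, because compound 1 has only a limit: the limit of > 20000 nM in this assay, at which 2 of the 4 values shown sit.

Going by these compounds, what remains open is which part of the entering group carries the step. A plain cyclohexylamino group, without the ring's amine, would test whether that amine is needed.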